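Moving the chlorine on the benzylidene ring

The source may hold more compounds than are shown below. What is called first, only, known or untested is meant among the compounds shown, and "the series" means these compounds.

Measured compounds:
compound 1, `O=C1N/C(=N\c2nccs2)S/C1=C\c1ccc(F)cc1`: 65.6%
compound 2, `Cc1csc(/N=C2\NC(=O)/C(=C/c3ccccc3Cl)S2)n1`: 43%

In a functional assay on the whole organism (strain AKR) for inhibition, with Mus musculus as the target, read by paw edema, with a stated time of 3.5 h, at a dose of 0.01 mmol/kg by the intraperitoneal route (a lower number here means less inhibition, a higher number more inhibition at the dose given (going by the name of the read-out)), compound 1 gives 65.6%. Compound 2 gives 43%, the lower of the two numbers, with compound 1 beyond the scatter above it. Compound 3, `Cc1csc(/N=C2\NC(=O)/C(=C/c3ccc(Cl)cc3)S2)n1`, differs from compound 2 by 4-chlorophenyl in place of 2-chlorophenyl on a double-bonded chain carbon bound to a double-bonded ring carbon. Going by the values given here, no measured pair shows this change on its own. Since compound 1, which also carries its halogen in the 4-position, gives 65.6%, a moderate rise for compound 3 is expected, estimated as a number 9 percentage points higher from compound 2 to compound 3 (within the scatter). Compound 3 is therefore expected to give about 52%, between 32% and 72%.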

Compound 3, a percentage reported as inhibition, in the whole organism at one dose (the size of the read-out at that dose, not a potency): 42%
The estimate for compound 3 lay 10 percentage points above the measured number; the range from low to high includes it.
By their numbers in this assay, from the lowest: compounds 3 and 2 (each within the scatter of the next); then compound 1.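

In this assay, 4-chlorophenyl in place of 2-chlorophenyl on a double-bonded chain carbon bound to a double-bonded ring carbon gives a number 1 percentage points lower from compound 2 to compound 3 (within the scatter), so at this dose the two chlorine placements are not told apart. Compound 1 differs from both in more than one place, so the steps to it cannot be read. Nothing shown offers a reason for this result. As far as these compounds go, whether a methoxy group or an amine in place of the chlorine would shift the number remains open. So does the contribution of the methyl group shared by compound 2 and compound 3.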